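Chlorine Position on the Benzylsulfanyl Arm of Compound 4

A few compounds are considered here, and "the series" means these few. Any claim that something is new, unique, unknown or untested is made for them only; others in the source may bear on it.

In a functional assay on the whole organism (artery, strain albino) with Rattus norvegicus as the target, with a stated time of 720 min, at a dose of 10 mg/kg by the oral route (a lower number here means less inhibition, a higher number more inhibition at the dose given (going by the name of the read-out)), compound 1 `COc1ccc(C2N=C(SCc3cccc(Cl)c3)NC(C)=C2C(=O)Nc2ccc(F)cc2)cc1OC` gives 15.5%. Compound 2 `COc1ccc(C2N=C(SCc3ccc(Cl)cc3)NC(C)=C2C(=O)Nc2ccc(F)cc2)cc1OC` carries 4-chlorophenyl in place of 3-chlorophenyl on a saturated chain carbon bound to a sulfur, and in this assay compound 2 gives 22.2%, which is a number 6.7 percentage points higher from compound 1 to compound 2 (within the scatter). Compound 3 `CC1=C(C(=O)Nc2ccc(F)cc2)C(c2ccc([N+](=O)[O-])cc2)N=C(SCc2cccc(Cl)c2)N1` has a core that differs from that of compound 1 by 4-nitrophenyl in place of 3,4-dimethoxyphenyl on a saturated ring carbon; in this assay compound 3 gives 12.9%, which is a number 2.6 percentage points lower from compound 1 to compound 3 (within the scatter). Among the measured compounds shown here, compound 4 `CC1=C(C(=O)Nc2ccc(F)cc2)C(c2ccc([N+](=O)[O-])cc2)N=C(SCc2ccc(Cl)cc2)N1` has not yet been measured and differs from compound 3 by 4-chlorophenyl in place of 3-chlorophenyl on a saturated chain carbon bound to a sulfur, the same change as the one from compound 1 to compound 2, made at the same place. Because the earlier step of a number 6.7 percentage points higher from compound 1 to compound 2 (within the scatter) stayed within the usual scatter, a step of about a number 6.1 percentage points higher from compound 3 to compound 4 (within the scatter) is expected here. Compound 4 is therefore estimated at 19% in this assay, with the expected range running from 6% to 32%.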

Compound 4, a percentage reported as inhibition, in the whole organism at one dose (the size of the read-out at that dose, not a potency): 22.2%
Compound 4: the middle estimate sits 3.2 percentage points below what was measured; the range from low to high includes it.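

In this assay, 4-chlorophenyl in place of 3-chlorophenyl on the core of compound 3 gives a number 9.3 percentage points higher from compound 3 to compound 4 (within the scatter), and the step reads alike on both cores: the same change on two cores in this assay, a number 6.7 percentage points higher (within the scatter) from compound 1 to compound 2 and a number 9.3 percentage points higher (within the scatter) from compound 3 to compound 4, 2.6 percentage points apart, within the scatter of two such steps. With the 4-chlorophenyl arm in place, 4-nitrophenyl in place of 3,4-dimethoxyphenyl gives no change at the digits printed from compound 2 to compound 4 (within the scatter), and this change also reads alike on both cores: the same change on two cores in this assay, a number 2.6 percentage points lower (within the scatter) from compound 1 to compound 3 and no change at the digits printed (within the scatter) from compound 2 to compound 4, 2.6 percentage points apart, within the scatter of two such steps. The two changes thus carry over between these cores, but every step lies within the scatter, so this does not show that either change alters the inhibition at all.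

The compounds shown leave open whether this holds beyond these four compounds. An unsubstituted benzyl or a longer chain on the sulfur could behave differently, as could a carboxylic acid in place of the nitro group.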